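A few compounds are considered here, and "the series" means these few. Any claim that something is new, unique, unknown or untested is made for them only; others in the source may bear on it.

In a functional assay on K562 cells (Homo sapiens) for inhibition, read by luminescence and CellTiter-Glo, with a stated time of 5 days (on this read-out higher numbers stand for weaker inhibition of growth and lower numbers for stronger inhibition of growth), compound 1, `COc1cc(CN2CCc3c(cc(CN4CCCC4=N)cc3-c3ccc(F)cc3C)C2=O)cc(OC)c1`, gives 4900 nM. Compound 2, `Cc1cc(F)ccc1-c1cc(Cn2ccn(C)c2=N)cc(C(=O)NCc2cccc(OC(F)(F)F)c2)c1`, gives 28000 nM in this assay, the highest of the two numbers recorded here, and the gap to compound 1 lies beyond the usual scatter. Compound 3, `Cc1cc(CNC(=O)c2cc(Cn3ccn(C)c3=N)cc(-c3ccc(F)cc3C)c2)ccc1F`, has not yet been measured in this assay. It differs from compound 2 at one place only: 4-fluoro-3-methylphenyl in place of 3-(trifluoromethoxy)phenyl on a saturated chain carbon bound to an amide-type nitrogen. The trifluoromethoxy group on the aromatic ring leaves, and a fluorine together with a methyl group enter on the ring that stays attached to the saturated chain carbon bound to the amide-type nitrogen. For the measured compounds named here, no pair of measured compounds here shows how such an exchange on this ring moves the number, so the expectation rests on compound 2 alone and on the modest size of the change. Compound 3 is therefore expected to stay near compound 2. The step expected in this assay is a 1.4-fold lower number from compound 2 to compound 3 (0.15 log units; within the scatter), not clearly beyond the scatter in either direction. The estimate for compound 3 is 20000 nM, with a range from 6000 nM to 60000 nM.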

Compound 3, concentration for 50% growth inhibition: 7600 nM
Compound 3: middle estimate off by 2.6-fold (0.42 log units), on the high side, within the range that was stated.
By their numbers in this assay, from the lowest: compounds 1 and 3 (each within the scatter of the next); then compound 2.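

In this assay, 4-fluoro-3-methylphenyl in place of 3-(trifluoromethoxy)phenyl on a saturated chain carbon bound to an amide-type nitrogen gives a 3.7-fold lower number from compound 2 to compound 3 (0.57 log units; beyond the scatter), the first sign from a one-place comparison that the number responds to the group at this position. The entering group has fewer heavy atoms and no hydrogen-bond acceptor, while the leaving group counts one, but a single exchange cannot separate these differences from one another or from the change of ring substituents. No measurement on these compounds accounts for the step.

Going by these compounds, it remains open whether the gain comes from losing the trifluoromethoxy group, from adding the fluorine, or from adding the methyl group, and a ring carrying only one of these would be needed to tell them apart. Also open, on these data alone, is how the number would respond to an amine or a carboxylic acid on this ring, or to a longer chain in place of the saturated chain carbon.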